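Replacing the Chlorophenyl Group in a Cyclic Amide Series

The source may hold more compounds than are shown below. What is called first, only, known or untested is meant among the compounds shown, and "the series" means these compounds.

Compound 1 `O=C(/N=C1\NC2(CCCCO2)CCS1)c1ccc(Cl)cc1`: 1.1 mg/kg
Compound 2 `O=C(/N=C1\NC2(CCCCO2)CCS1)c1ccc([N+](=O)[O-])cc1`: 28 mg/kg
Compound 3 `N#Cc1ccc(C(=O)/N=C2\NC3(CCCCO3)CCS2)cc1`: 60 mg/kg

In a functional assay on the whole organism (strain CF-1) with Mus musculus as the target, in the writhing test, with a stated time of 15 min (a higher number here means that more compound is needed for the effect, a lower number that less compound is needed), compound 1 stands lowest of the three measured values. The steps of a 25-fold higher number from compound 1 to compound 2 (1.41 log units; beyond the scatter) and a 55-fold higher number from compound 1 to compound 3 (1.74 log units; beyond the scatter) both run upward and both lie beyond the scatter. Compound 4 `O=C(/N=C1\NC2(CCCCO2)CCS1)c1ccccc1O` differs from compound 1 by 2-hydroxyphenyl in place of 4-chlorophenyl on a carbonyl carbon. Going by the values given here, neither measured step exchanges the chlorophenyl group for a hydroxyphenyl group, so no step bears on this change directly; the only guide is that every measured departure from compound 1 gave a higher number in this assay. Compound 4 is therefore expected to need more compound than compound 1, a step of a 7.3-fold higher number from compound 1 to compound 4 (0.86 log units; beyond the scatter), with wide uncertainty. The estimate for compound 4 in this assay is 8 mg/kg, within a range from 1.5 mg/kg to 45 mg/kg.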

Compound 4, dose for half-maximal effect: > 200 mg/kg
Compound 4 was reported as a limit; the forecaster's own chance of this, stated with the estimate: 10%; middle value at least 25-fold (1.39 log units) from the limit.
By their numbers in this assay, from the lowest: compound 1; then compound 2; then compound 3. At a limit, above all of these: compound 4.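

In this assay compound 4 gives > 200 mg/kg, which is a limit of the assay and not a number. Exchanging the whole 4-chlorophenyl group for 2-hydroxyphenyl on the carbonyl carbon gives an at least 180-fold higher number from compound 1 to compound 4 (2.25 log units; beyond the scatter), so change at this position can cost more than the nitro and cyano exchanges showed. Only compound 4 reaches this limit: the limit of > 200 mg/kg in this assay, at which 1 of the 4 values shown sits.

The compounds shown do not separate the effect of the hydroxy group from that of its place on the ring. A 4-hydroxyphenyl, 2-chlorophenyl or 2-methoxyphenyl group would bear on that question.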